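The source may report more compounds than this note shows. Statements on the series, on what has been measured and on what is new or still open speak of the compounds shown alone.

- Compound 1 `CC(O)(CSc1ccc(F)cc1)C(=O)Nc1ccc(S(F)(F)(F)(F)F)cc1`: 25400 nM
- Compound 2 `CC(O)(CSc1cccc(C(F)(F)F)c1)C(=O)Nc1ccc(S(F)(F)(F)(F)F)cc1`: 26200 nM

In a functional assay on DU-145 cells (Homo sapiens) for antiproliferative activity, read by propidium iodide staining, with a stated time of 96 h (on this read-out higher numbers stand for weaker inhibition and lower numbers for stronger inhibition), compound 2 gives 26200 nM and sits level with compound 1 at 25400 nM, so the two cannot be told apart. Compound 3 `CC(O)(CSc1ccc(C(F)(F)F)cn1)C(=O)Nc1ccc(S(F)(F)(F)(F)F)cc1` differs from compound 2 as follows: 5-(trifluoromethyl)pyridin-2-yl in place of 3-(trifluoromethyl)phenyl on a sulfur. In words, 5-(trifluoromethyl)pyridin-2-yl stands in place of 3-(trifluoromethyl)phenyl on a sulfur. Within the data shown here, the only measured step, a 1.0-fold higher number from compound 1 to compound 2 (0.01 log units; within the scatter), also exchanges the group on the sulfur and stays within the scatter. Neither measured compound has a hetero atom in that ring, so this evidence is thin, and the range is kept wide. The expected change is a 1.0-fold lower number from compound 2 to compound 3 (0.02 log units; within the scatter), which means none beyond the scatter. For compound 3 the estimated value is 25000 nM, with an expected range of 10000 nM to 60000 nM.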

Compound 3, half-maximal inhibitory concentration: 30700 nM
Estimate against measurement, compound 3: 1.2-fold (0.09 log units) below, and the stated range covers the measured number.
By their numbers in this assay, from the lowest: compounds 1, 2 and 3 (each within the scatter of the next).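

Among these compounds, a ring nitrogen in the group on the sulfur appears here for the first time, and in this assay it makes no difference that can be read: a 1.2-fold higher number from compound 2 to compound 3 (0.07 log units; within the scatter), and a 1.2-fold higher number from compound 1 to compound 3 (0.08 log units; within the scatter). So 5-(trifluoromethyl)pyridin-2-yl, with 1 hydrogen-bond acceptor where 3-(trifluoromethyl)phenyl has 0, sits level with both phenyl groups. No measurement on hand offers an explanation for this result. The compounds shown leave open whether an amine or a carboxylic acid on this ring, or a plain alkyl chain replacing the ring, would give a number beyond the scatter.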